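This account rests on a few compounds, and the source may have more. Where it says the series, first, only, none or still open, it means among the compounds named here.

Compound 3, `COc1ccc(/C=C/C(=O)/C=C/C2=C(C)CCCC2(C)C)cc1`, gives the lowest number among the three measured compounds in a functional assay on HeLa cells (Homo sapiens) for cytotoxicity, read by sulforhodamine B assay, with a stated time of 48 h (a higher number here means a weaker inhibitor, a lower number a stronger inhibitor), where compound 3 gives 15700 nM. Its two neighbours differ from it only in the group on the aromatic ring: compound 1, `CC1=C(/C=C/C(=O)/C=C/c2ccc(Cl)cc2)C(C)(C)CCC1`, gives 33200 nM in this assay, and compound 2, `CC1=C(/C=C/C(=O)/C=C/c2ccc(F)cc2)C(C)(C)CCC1`, gives 32200 nM. The steps of a 2.1-fold lower number from compound 1 to compound 3 (0.33 log units; beyond the scatter) and a 2.1-fold lower number from compound 2 to compound 3 (0.31 log units; beyond the scatter) are both modest but beyond the scatter, whereas a 1.0-fold lower number from compound 1 to compound 2 (0.01 log units; within the scatter) stays within it.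

Compound 4, `CC1=C(/C=C/C(=O)/C=C/c2ccc(C)cc2)C(C)(C)CCC1`, carries the change (methyl in place of methoxy on an aromatic carbon). Among the measured compounds shown here, the measured steps bearing on it are the two that exchange the group at this same position, both in favour of the methoxy group; no measured compound carries a methyl there, so the direction of this step rests on analogy alone. Since replacing halogen by methoxy lowered the number modestly, swapping methoxy for methyl is expected to move it back somewhat, a step of about a 1.6-fold higher number from compound 3 to compound 4 (0.20 log units; within the scatter). Compound 4 is therefore expected to give roughly 25000 nM in this assay, with a range of 12000 nM to 50000 nM.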

Compound 4, half-maximal inhibitory concentration: 20400 nM
Estimate against measurement, compound 4: 1.2-fold (0.09 log units) above, within the range that was stated.
By their numbers in this assay, from the lowest: compounds 3, 4, 2 and 1 (each within the scatter of the next, the first and the last beyond it).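

In this assay the methyl group of compound 4 cannot be told apart from any of the other three groups at this position: the step of a 1.3-fold higher number from compound 3 to compound 4 (0.11 log units; within the scatter) and the step of a 1.6-fold lower number from compound 2 to compound 4 (0.20 log units; within the scatter) and also the step of a 1.6-fold lower number from compound 1 to compound 4 (0.21 log units; within the scatter) all stay within the scatter. The earlier compounds shown here showed methoxy modestly separated from both halogens, but methyl is separated from neither side, so the four groups do not fall into two clear sets. Nothing available here explains this result.

From the compounds shown here alone, it remains open whether an amine, a carboxylic acid or a longer chain such as butoxy at this position would move the number further than these four groups do. Going by these compounds, it also remains open how much of the level of these numbers comes from the shared core rather than from this group.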